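The source may report more compounds than this note shows. Statements on the series, on what has been measured and on what is new or still open speak of the compounds shown alone.

Values in a physicochemical assay for lipophilicity; on this read-out lower numbers stand for lower lipophilicity and higher numbers for higher lipophilicity:
- compound 1 `COc1ccc(C2=NO[C@]3(C2)C(=O)O[C@@H]2[C@H]3CC[C@H](C)[C@]3(O)C=CC(=O)[C@@]23C)cc1`: 1.47
- compound 2 `C[C@H]1CC[C@@H]2[C@@H](OC(=O)[C@]23CC(c2ccc(Cl)cc2)=NO3)[C@]2(C)C(=O)C=C[C@@]12O`: 2.09
- compound 3 `C[C@H]1CC[C@@H]2[C@@H](OC(=O)[C@]23CC(c2ccccc2[N+](=O)[O-])=NO3)[C@]2(C)C(=O)C=C[C@@]12O`: 1.37

Compound 3 sits at the low end of the set, level with compound 1: the measured step is a number 0.10 log units lower from compound 1 to compound 3 (within the scatter). Against compound 2 the gap is wider, a number 0.72 log units lower from compound 2 to compound 3 (beyond the scatter).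

Compound 4 `C[C@H]1CC[C@@H]2[C@@H](OC(=O)[C@]23CC(c2ccccc2F)=NO3)[C@]2(C)C(=O)C=C[C@@]12O` follows from compound 3 by fluoro in place of nitro on an aromatic carbon, ortho to a large group.

Within the data shown here, no measured step introduces fluoro. The nearest guides are that step from compound 2 and a number 0.62 log units higher from compound 1 to compound 2 (beyond the scatter), both modest. A rise in this assay is therefore expected, smaller than the gap separating compound 3 from the chloro compound 2. The expected step is a number 0.35 log units higher from compound 3 to compound 4 (beyond the scatter). The estimate for compound 4 is 1.72, with an expected range of 1.42 to 2.02.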

Compound 4, partition coefficient: 1.58
Estimate against measurement, compound 4: 0.14 log units above, within the range that was stated.
By their numbers in this assay, from the lowest: compounds 3, 1 and 4 (each within the scatter of the next); then compound 2.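

In this assay, the change from 2-nitrophenyl to 2-fluorophenyl, with three heavy atoms leaving and one entering, does not separate the two compounds (a number 0.21 log units higher from compound 3 to compound 4 (within the scatter)). Compound 4 is also not separated from the 4-methoxyphenyl compound (a number 0.11 log units higher from compound 1 to compound 4 (within the scatter)), whereas the 4-chlorophenyl compound stays apart (a number 0.51 log units lower from compound 2 to compound 4 (beyond the scatter)). No supporting evidence bears on these differences.

Still open, from the compounds shown here alone, is whether the step from 4-chlorophenyl to 2-fluorophenyl follows the group or its place on the ring. Going by these compounds, how an amine or a carboxylic acid would read at this position is also open.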